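Swapping the ring on the thiocarbonyl carbon in compound 3

A few compounds are considered here, and "the series" means these few. Any claim that something is new, unique, unknown or untested is made for them only; others in the source may bear on it.

Of the compounds shown here, three have been measured in a functional assay on MCF7 cells (Homo sapiens) for cytotoxicity, read by MTT assay, with a stated time of 72 h, tested at 3 uM; on this read-out lower numbers stand for less inhibition of growth and higher numbers for more inhibition of growth at the one concentration tested. Compound 1 `Cc1cccc(/C(N)=N/NC(=S)N2CCSCC2)n1` gives 20.6%, compound 2 `N/C(=N\NC(=S)N1CCCCC1)c1ccccn1` gives 38.6%, and compound 3 `Cc1cccc(/C(N)=N/NC(=S)N2CCOCC2)n1` gives 21.6%. Compound 3 therefore stands second highest of the three numbers: its nearest neighbour is compound 1, separated by a gap that sits within the scatter, and its furthest is compound 2, which lies beyond the scatter above it.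

The next compound, compound 4 `Cc1cccc(/C(N)=N/NC(=S)N2CCCCC2)n1`, is reached from compound 3 by a single change: piperidin-1-yl in place of morpholin-4-yl on a thiocarbonyl carbon. Among the compounds with values here, only one measured step bears on the same position, namely a number 1 percentage points higher from compound 1 to compound 3 (within the scatter), and that step stayed within the scatter. Compound 2 also carries piperidin-1-yl on its thiocarbonyl carbon but differs from compound 4 elsewhere in the shared core. In this assay compound 2 gives 38.6%, which can only hint that the higher region is reachable in this assay.

Given the flat step from compound 1 to compound 3 and the higher reading of compound 2, compound 4 is expected to move by about a number 5.4 percentage points higher from compound 3 to compound 4 (within the scatter), an estimated 27% with a range from 14% to 40%.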

Compound 4, percent growth inhibition at one concentration: 27.1%
The estimate for compound 4 lay 0.1 percentage points below the measured number; low and high end bracket the measured number.
By their numbers in this assay, from the lowest: compounds 1, 3 and 4 (each within the scatter of the next); then compound 2.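

In this assay the ring on the thiocarbonyl carbon can now be compared across three members on one core: piperidin-1-yl in place of morpholin-4-yl gives a number 5.5 percentage points higher from compound 3 to compound 4 (within the scatter) and piperidin-1-yl in place of thiomorpholin-4-yl gives a number 6.5 percentage points higher from compound 1 to compound 4 (within the scatter), so this read-out does not tell the three rings apart. Within the data shown here, the first change to pass the scatter lies elsewhere, since methyl in place of hydrogen on an aromatic carbon gives a number 11.5 percentage points lower from compound 2 to compound 4 (beyond the scatter), a modest step that shows the aromatic carbon matters more here than the ring swaps do. Nothing at hand accounts for either the flat ring steps or the methyl step.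

On these data alone, the methyl step rests on a single pair carrying piperidin-1-yl, so whether it would hold with morpholin-4-yl or thiomorpholin-4-yl on the thiocarbonyl carbon stays open. Also open, as far as these compounds go, is how a piperazin-1-yl ring or an open-chain dimethylamino group would read on that carbon, and how an ethyl or methoxy group would read in place of methyl on the aromatic carbon.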